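A few compounds are considered here, and "the series" means these few. Any claim that something is new, unique, unknown or untested is made for them only; others in the source may bear on it.

Measured so far:
compound 1, `O=C1O[C@H]([C@@H](O)Cn2cc(-c3cc(F)cc(F)c3)nn2)C(OCc2ccccc2)=C1OCc1ccccc1`, > 100000 nM
compound 2, `O=C1O/C(=C\Cn2cc(-c3cccc(O)c3)nn2)C(OCc2ccccc2)=C1OCc1ccccc1`, 42600 nM

Both compounds were tested in an ADME assay on HFF cells (Homo sapiens) for cytotoxicity, read by MTT assay, with a stated time of 72 h; on this read-out higher numbers stand for weaker inhibition and lower numbers for stronger inhibition. For compound 1 the result is a limit rather than a number, > 100000 nM (the limit of > 100000 nM in this assay, at which 1 of the 2 values shown sits). Compound 2 gives 42600 nM in this assay. Compound 3, `O=C1O[C@H]([C@@H](O)Cn2cc(CCCCl)nn2)C(OCc2ccccc2)=C1OCc1ccccc1`, has not yet been measured there. It differs from compound 1 in one place: 3-chloropropyl in place of 3,5-difluorophenyl on an aromatic carbon. For the measured compounds named here, no step between two measured compounds is available here, so there is no measured change of this kind to lean on. The step expected in this assay is a number no higher from compound 1 to compound 3 (the limit leaves the size open), a change that would stay within the usual scatter. On that basis compound 3 is expected to sit around 100000 nM, with a range from 50000 nM to 300000 nM, and most likely to be reported only as a limit again.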

Compound 3, half-maximal inhibitory concentration: 27100 nM
Beside the measured number, compound 3's estimate is 3.7-fold (0.57 log units) above it; measured number below the stated range.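

In this assay, putting 3-chloropropyl in place of 3,5-difluorophenyl on this aromatic carbon of the five-membered ring gives an at least 3.6-fold lower number from compound 1 to compound 3 (0.56 log units; beyond the scatter). A lower number here means stronger inhibition, so this position is not indifferent to the group it carries, and the change from a ring to a chain makes the compound more toxic to these cells. The true size of the step stays open because compound 1 is recorded only as a limit, not as a number: the limit of > 100000 nM in this assay, at which 1 of the 3 values shown sits.

This single change replaces a ring with a chain and fluorine with chlorine together, so the compounds shown cannot say which of these matters. From the compounds shown here alone, a plain propyl chain or an unsubstituted phenyl ring could separate the two, and how an amine at the end of the chain would read also remains open.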